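Replacing a Methoxycarbonyl Group with an Amino Group

A few compounds are considered here, and "the series" means these few. Any claim that something is new, unique, unknown or untested is made for them only; others in the source may bear on it.

Two measured relatives share one core and differ only in a single group on the aromatic ring. Compound 1 `Cc1cncc(OC[C@@H]2CCCN2C)c1` carries a methyl there, and in an assay on membranes from brain for displacement of a labelled ligand from Neuronal acetylcholine receptor; alpha4/beta2 (Rattus norvegicus) (a higher number here means a weaker inhibitor, a lower number a stronger inhibitor), compound 1 gives 0.48 nM. Compound 2 `COC(=O)c1cncc(OC[C@@H]2CCCN2C)c1` carries a methoxycarbonyl in the same place, and in this assay compound 2 gives 1.45 nM. Within the data shown here, of the two numbers so far, compound 2 has the higher one, the only step being a 3.0-fold higher number from compound 1 to compound 2 (0.48 log units; beyond the scatter). Compound 3 `CN1CCC[C@H]1COc1cncc(N)c1` is not yet measured; the change is amino in place of methoxycarbonyl on an aromatic carbon. Among the measured compounds shown here, no measured step involves an amino group, so the methyl-to-methoxycarbonyl step is only an indirect guide: it shows that a change at this site moves the number by a modest amount. Compound 3 is therefore expected to give about 0.8 nM, within a range from 0.3 nM to 2.5 nM. This estimate implies an expected step of a 1.8-fold lower number from compound 2 to compound 3 (0.26 log units; within the scatter).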

Compound 3, inhibition constant: 0.63 nM
For compound 3 the middle estimate is 1.3-fold (0.10 log units) above the measured one; the range from low to high includes it.
By their numbers in this assay, from the lowest: compounds 1 and 3 (each within the scatter of the next); then compound 2.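

Putting amino in place of methoxycarbonyl gives a 2.3-fold lower number from compound 2 to compound 3 (0.36 log units; beyond the scatter) in this assay, so a group of one heavy atom serves this position better than the four-atom ester. Compared with the methyl, the amino gives a 1.3-fold higher number from compound 1 to compound 3 (0.12 log units; within the scatter), which leaves the two groups indistinguishable here, although amino carries a hydrogen-bond donor and methoxycarbonyl carries none. Across these three compounds, then, methoxycarbonyl alone stands apart, and the position accepts both methyl and amino without a change beyond the scatter. Nothing in the data explains why these groups rank as they do. Going by these compounds, it also remains open whether a dimethylamino group, a carboxylic acid or a longer alkyl chain at this position would track with the methyl and amino or with the methoxycarbonyl.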